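The source may hold more compounds than are shown below. What is called first, only, known or untested is meant among the compounds shown, and "the series" means these compounds.

Compound 3, with structure `COc1cc(C(=O)c2cc(OC)c(OC)c(OC)c2)cc(NC(=O)/C=C/c2ccc(C(F)(F)F)cc2)c1OC`, gives the lowest number of the three compounds measured in a functional assay on COLO 205 cells (Homo sapiens) for cytotoxicity, read by MTT assay, with a stated time of 72 h (a lower number here means a stronger inhibitor, a higher number a weaker inhibitor), at 2500 nM. Compound 1, structure `COc1ccc(/C=C/C(=O)Nc2cc(C(=O)c3cc(OC)c(OC)c(OC)c3)cc(OC)c2OC)cc1OC`, gives 5700 nM in this assay, and compound 2, structure `COc1ccc(/C=C/C(=O)Nc2cc(C(=O)c3cc(OC)c(OC)c(OC)c3)cc(OC)c2OC)cc1N`, gives 10100 nM. On this assay the step of a 2.3-fold lower number from compound 1 to compound 3 (0.36 log units; beyond the scatter) and the step of a 4.0-fold lower number from compound 2 to compound 3 (0.61 log units; beyond the scatter) both lie beyond the scatter, so compound 3 stands apart from the other two, though only modestly so.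

Compound 4, structure `COc1cc(C(=O)c2cc(OC)c(OC)c(OC)c2)cc(NC(=O)/C=C/c2cc(F)c(F)c(F)c2)c1OC`, differs from compound 3 at the same place where compounds 1, 2 and 3 differ from one another: 3,4,5-trifluorophenyl in place of 4-(trifluoromethyl)phenyl on a double-bonded chain carbon bound to a double-bonded chain carbon. The two steps that bear on this change, a 2.3-fold lower number from compound 1 to compound 3 (0.36 log units; beyond the scatter) and a 4.0-fold lower number from compound 2 to compound 3 (0.61 log units; beyond the scatter), show that swapping the aryl on the double-bonded chain carbon moves the number by only a modest amount. Going by the values given here, neither of them involves the 3,4,5-trifluorophenyl group, so there is no direct precedent for its effect. Given this, the step of a 1.2-fold higher number from compound 3 to compound 4 (0.08 log units; within the scatter) is expected to be small, with no clear direction beyond the scatter. Compound 4 is therefore estimated to give 3000 nM in this assay, with a plausible range from 1000 nM to 9000 nM.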

Compound 4, half-maximal inhibitory concentration: 4300 nM
Beside the measured number, compound 4's estimate is 1.4-fold (0.16 log units) below it; measured number inside the range.
By their numbers in this assay, from the lowest: compounds 3, 4, 1 and 2 (each within the scatter of the next, the first and the last beyond it).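

In this assay, going by these compounds alone, the first group with fluorine directly on the ring gives a 1.7-fold higher number from compound 3 to compound 4 (0.24 log units; within the scatter), so 3,4,5-trifluorophenyl and 4-(trifluoromethyl)phenyl cannot be told apart at this position on a double-bonded chain carbon bound to a double-bonded chain carbon. The same replacement gives a 2.3-fold lower number from compound 2 to compound 4 (0.37 log units; beyond the scatter) against the 3-amino-4-methoxyphenyl group but a 1.3-fold lower number from compound 1 to compound 4 (0.12 log units; within the scatter) against 3,4-dimethoxyphenyl, so compound 4 separates from compound 2 while remaining within the scatter of compound 1, which compound 3 does not. The three-fluorine aryl group therefore does not reproduce the full separation from compound 1 that the trifluoromethyl group showed, although the small gap between compound 3 and compound 4 means the two aryl groups are not shown to differ, and no supporting evidence bears on why the numbers fall as they do.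

The compounds shown leave open whether a nitrile or a chlorine on the phenyl ring, or a carboxylic acid there, would move the number further than these aryl swaps have. They also leave open whether an aromatic ring is needed at this place at all, as a longer alkyl chain in its stead would test.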